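The compounds below may be only part of what the source reports. "The series", "measured", "known", "first", "only" and "open" are said of these compounds alone.

Working notes on the series. Compound 3 `C[C@H](Nc1ncnc2[nH]cnc12)c1nn(-c2cccnc2)c2cc(Cl)ccc12` stands highest of the three numbers in a functional assay on Bel-7402 cells (Homo sapiens) for inhibition, read by sulforhodamine B assay, with a stated time of 72 h, tested at 10 uM (on this read-out higher numbers stand for more inhibition at the one concentration tested (going by the name of the read-out) and lower numbers for less inhibition), where compound 3 gives 17%. Compound 2 `Cc1ccc2c(c1)c([C@H](C)Nc1ncnc3[nH]cnc13)nn2-c1cccnc1` gives -10% in this assay, and compound 1 `C[C@H](Nc1ncnc2[nH]cnc12)c1nn(-c2cccnc2)c2ccc(F)cc12` gives -22%. Among the measured compounds shown here, the one step between measured compounds, a number 12 percentage points higher from compound 1 to compound 2 (beyond the scatter), concerns a methyl in place of fluoro at a different position and so bears only loosely on the present change. Compound 4 `C[C@H](Nc1ncnc2[nH]cnc12)c1nn(-c2cccnc2)c2cc(F)ccc12` differs from compound 3 by fluoro in place of chloro on an aromatic carbon. For the measured compounds named here, no measured step compares chloro against fluoro at this position; compound 1 carries fluoro elsewhere and sits low. A downward step, a number 17 percentage points lower from compound 3 to compound 4 (beyond the scatter), is therefore expected, with wide uncertainty. For compound 4 the estimate in this assay is 0%, expected between -25% and 25%.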

Compound 4, a percentage reported as inhibition, at one concentration (the size of the read-out at that concentration, not a potency): 8%
Compound 4: the middle estimate sits 8 percentage points below what was measured; the measured number falls inside the stated range.
By their numbers in this assay, from the lowest: compound 1; then compound 2; then compounds 4 and 3 (each within the scatter of the next).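

Chloro and fluoro at this position can now be compared directly: in this assay the change gives a number 9 percentage points lower from compound 3 to compound 4 (within the scatter) and so does not separate the two halogens. Swapping one for the other here leaves the low level of inhibition of compound 3 essentially in place. Nothing at hand explains this result. Still open, from the compounds shown here alone, is whether a non-halogen group at this position, such as an amine, a methoxy group or a carboxylic acid, would give a number beyond the scatter from that of compound 3. Also open, going by these compounds, is how bromo or trifluoromethyl would read here.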